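Swapping a Ring Nitrogen Substituent for Methyl

A few compounds are considered here, and "the series" means these few. Any claim that something is new, unique, unknown or untested is made for them only; others in the source may bear on it.

Measured so far:
compound 1, `CN1C(=O)/C(=C/N2N=C(c3ccccc3)CC2c2ccccc2O)SC1=S`, 341 nM
compound 2, `CC(=O)Oc1ccc(N2C(=O)/C(=C/N3N=C(c4ccc5ccccc5c4)CC3c3ccccc3O)SC2=S)cc1`, > 10000 nM

In a functional assay on SK-OV-3 cells (Homo sapiens) for antiproliferative activity, read by MTT assay, with a stated time of 72 h (a higher number here means a weaker inhibitor, a lower number a stronger inhibitor), compound 1 gives 341 nM. Compound 2 reaches no number in this assay; its value of > 10000 nM is a limit of the assay, and the limit of > 10000 nM in this assay, at which 1 of the 2 values shown sits, marks where it sits. Compound 3, `CN1C(=O)/C(=C/N2N=C(c3ccc4ccccc4c3)CC2c2ccccc2O)SC1=S`, is not yet measured. It differs from compound 2 by methyl in place of 4-acetoxyphenyl on an amide-type nitrogen in a ring. Among the compounds with values here, no measured pair separates this change on its own, so its size has to be guessed. Compound 1 carries a methyl on that same ring nitrogen and gives 341 nM, so the methyl-bearing compound 3 is expected to move toward a stronger inhibitor, a step of an at least 5.0-fold lower number from compound 2 to compound 3 (0.69 log units; beyond the scatter). Compound 3 is estimated at 2000 nM, within a range from 400 nM to 10000 nM.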

Compound 3, half-maximal inhibitory concentration: > 10000 nM
Compound 3: no number, only a limit; the forecaster's own chance of this, stated with the estimate: 25%; middle value at least 5.0-fold (0.69 log units) away from the limit.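

As far as these compounds go, compound 3 also ends at a limit of the assay, so the step from compound 2 cannot be read and the effect of methyl in place of 4-acetoxyphenyl on the ring nitrogen remains unknown. The readable comparison is at the other position: with methyl on the ring nitrogen in both compounds, naphthalen-2-yl in place of phenyl on the carbon with a double bond to nitrogen gives an at least 29-fold higher number from compound 1 to compound 3 (1.46 log units; beyond the scatter) in this assay. Methyl on that nitrogen therefore does not ensure a measurable value, and both naphthalen-2-yl compounds sit at the same end of the scale: the limit of > 10000 nM in this assay, at which 2 of the 3 values shown sit.

From the compounds shown here alone, it remains open whether 4-acetoxyphenyl on the ring nitrogen would be tolerated with phenyl on that carbon. Going by these compounds, it is also open whether a 4-fluorophenyl group on that carbon would stay close to compound 1.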